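The source may hold more compounds than are shown below. What is called first, only, known or untested is meant among the compounds shown, and "the series" means these compounds.

Three measured compounds and one not yet measured share a single amide core. Compound 1 `CCS(=O)(=O)Nc1ccc(NC(=O)c2cccc(C(F)(F)F)c2)cc1OC`, compound 2 `COc1cc(NC(=O)c2cccc(C(F)(F)F)c2)ccc1NS(=O)(=O)C(F)(F)F` and compound 3 `COc1cc(NC(=O)c2cc(C(F)(F)F)cc(C(F)(F)F)c2)ccc1NS(=O)(=O)C(F)(F)F` were tested in an ADME assay on HEK293 cells (Homo sapiens) for cytotoxicity, read by MTT assay, with a stated time of 48 h; a higher number here means a weaker inhibitor, a lower number a stronger inhibitor. In this assay compound 1 gives > 250000 nM, which is a limit of the assay and not a number. In this assay compound 2 likewise stops at the limit of > 250000 nM. In this assay compound 3 also stops at the limit of > 250000 nM. The step that the two limits leave unreadable from compound 1 to compound 2 and the step that the two limits leave unreadable from compound 2 to compound 3 cannot be sized, because the limit of > 250000 nM in this assay, at which 3 of the 3 values shown sit, leaves every end of them unmeasured. Compound 2 therefore stands at that limit, with nothing placing it apart from the other two. Compound 4 `O=C(Nc1ccc(NS(=O)(=O)C(F)(F)F)c(F)c1)c1cccc(C(F)(F)F)c1` differs from compound 2 by fluoro in place of methoxy on an aromatic carbon. Neither measured step touches this exchange, and neither could be read, so no change beyond the scatter is expected. The expected step is a step that the limit leaves unreadable from compound 2 to compound 4. Compound 4 is accordingly estimated at 300000 nM, within a range from 100000 nM to 1000000 nM, most probably again reported only as a limit.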

Compound 4, half-maximal inhibitory concentration: 152000 nM
For compound 4 the middle estimate is 2.0-fold (0.30 log units) above the measured one; the measured number falls inside the stated range.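

For the compounds shown here, on an aromatic carbon ortho to a ((trifluoromethyl)sulfonyl)amino group, fluoro in place of methoxy gives the only step here with a readable size: an at least 1.6-fold lower number from compound 2 to compound 4 (0.21 log units; that floor lies within the scatter). Compound 2 stands only at a limit, so this size is a floor, and the floor alone does not set compound 4 apart from compound 2 beyond the scatter. The other steps cannot be read: the limit of > 250000 nM in this assay, at which 3 of the 4 values shown sit.

Going by these compounds, what a chloro, hydroxy or amino group on this same aromatic carbon would give in this assay remains open. Also open, on these data alone, is whether fluoro in place of methoxy would bring a number rather than a limit alongside the ethyl on the sulfonyl sulfur of compound 1, or alongside the second trifluoromethyl of compound 3.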